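The source may report more compounds than this note shows. Statements on the series, on what has been measured and on what is new or still open speak of the compounds shown alone.

Three compounds share one core and differ only in the group on the aromatic carbon of the six-membered carbon ring. Compound 1, `Cc1nc(-c2ccc(C(F)(F)F)cc2)sc1CNc1ccc(CCCC(=O)O)cc1`, carries a 3-carboxypropyl group. In a functional assay on CHO cells for agonist activity at Free fatty acid receptor 1 (Homo sapiens) (on this read-out higher numbers stand for an effect only at larger amounts of compound and lower numbers for an effect already at smaller amounts), compound 1 gives < 10000 nM, which is a limit of the assay and not a number. Compound 2, `Cc1nc(-c2ccc(C(F)(F)F)cc2)sc1CNc1ccc(CC(C)C(=O)O)cc1`, gives 355 nM in this assay. Among the compounds with values here, compound 3, `Cc1nc(-c2ccc(C(F)(F)F)cc2)sc1CNc1ccc(C(C)CC(=O)O)cc1`, gives 58.9 nM in this assay, the lowest of the two numbers, with a 6.0-fold lower number from compound 2 to compound 3 (0.78 log units; beyond the scatter) as the only readable step. The steps a step that the limit leaves unreadable from compound 1 to compound 2 and a step that the limit leaves unreadable from compound 1 to compound 3 cannot be sized because of the limit of < 10000 nM in this assay, at which 1 of the 3 values shown sits.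

Compound 4, `Cc1nc(-c2ccc(C(F)(F)F)cc2)sc1CNc1ccc([C@H]2C[C@@H]2C(=O)N(C)C)cc1`, is not yet measured. The change is 2-(dimethylcarbamoyl)cyclopropyl in place of 1-(carboxymethyl)ethyl on an aromatic carbon. Within the data shown here, every measured step moved the carboxylic acid along a chain but kept it; none removed it or introduced a three-membered ring or an amide, so no measured step bears directly on this change. The expectation therefore rests on little and is uncertain; a higher number than compound 3 is expected, with a wide range, as the step of a 14-fold higher number from compound 3 to compound 4 (1.13 log units; beyond the scatter). The value expected for compound 4 is 800 nM, between 60 nM and 10000 nM.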

Compound 4, half-maximal effective concentration: 66.1 nM
The estimate for compound 4 lay 12-fold (1.08 log units) above the measured number, within the range that was stated.
By their numbers in this assay, from the lowest: compounds 3 and 4 (each within the scatter of the next); then compound 2.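

In this assay, replacing 1-(carboxymethyl)ethyl on the aromatic carbon with 2-(dimethylcarbamoyl)cyclopropyl gives a 1.1-fold higher number from compound 3 to compound 4 (0.05 log units; within the scatter). Compound 4 therefore shows what compounds 1 to 3, which all carry a carboxylic acid, could not: at this position, a low number does not depend on that acid, and the amide-bearing three-membered ring is accepted, with a 5.4-fold lower number from compound 2 to compound 4 (0.73 log units; beyond the scatter). Compound 1 gives a limit and not a number, and its step to compound 4 cannot be read because of this: the limit of < 10000 nM in this assay, at which 1 of the 4 values shown sits.

The ring and the dimethylcarbamoyl group enter together, and the compounds shown do not separate them; a cyclopropyl ring bearing a carboxylic acid, or an open chain ending in a dimethyl amide, would do so. Also open, as far as these compounds go, is how the opposite arrangement at the two defined stereocentres would read.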